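Replacing a Chlorophenyl Group with a Pentyl Chain

The compounds below may be only part of what the source reports. "The series", "measured", "known", "first", "only" and "open" are said of these compounds alone.

Measured compounds:
- Compound 1, `CCc1nncn1-c1ccc(OCc2c(F)cccc2F)cc1`, 15.8 mg/kg
- Compound 2, `CCc1nncn1-c1ccc(OCc2ccccc2Cl)cc1`, 13.2 mg/kg
- Compound 3, `CCc1nncn1-c1ccc(OCc2ccc(OC)cc2)cc1`, 15.8 mg/kg

All three compounds were tested in a functional assay on the whole organism (strain C57B/6) with Mus musculus as the target, in the maximal electroshock model; on this read-out lower numbers stand for an effect already at smaller amounts and higher numbers for an effect only at larger amounts of compound. Compound 2 gives the lowest of the three numbers, yet compound 1 and compound 3 both sit within the usual scatter of it, so the three values cannot be told apart on this read-out. Among the measured compounds shown here, no single-point step between these measured compounds is available, since each pair differs in more than one place.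

Compound 4, `CCCCCCOc1ccc(-n2cnnc2CC)cc1`, has not yet been measured in this assay. Relative to compound 2 the change is pentyl in place of 2-chlorophenyl on a saturated chain carbon bound to an oxygen on an aromatic ring: a pentyl chain in place of the 2-chlorophenyl group on a saturated chain carbon bound to an oxygen on an aromatic ring. Among the measured compounds this position always carries a ring, and the three ring variants give values that lie within the scatter of one another. Swapping the ring for an open chain is a larger change than any seen so far, for which no precedent exists among the measured compounds. The writer therefore expects a step from compound 2 to compound 4 of a 2.1-fold higher number from compound 2 to compound 4 (0.33 log units; beyond the scatter), toward a higher number, with wide uncertainty. For compound 4 the expected value in this assay is 28 mg/kg, within a range from 9 mg/kg to 90 mg/kg.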

Compound 4, dose for half-maximal effect: 13.2 mg/kg
The estimate for compound 4 lay 2.1-fold (0.33 log units) above the measured number, within the range that was stated.
By their numbers in this assay, from the lowest: compounds 2, 4, 1 and 3 (each within the scatter of the next).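

In this assay, putting a pentyl chain where the 2-chlorophenyl group stood gives no change at the digits printed from compound 2 to compound 4 (within the scatter), so this one change leaves the read-out where it was. The earlier compounds shown here all carried a ring at this position and could only show that ring variants lie within the scatter of one another, whereas this pair shows that the six-membered aromatic ring and its chlorine can leave and an open chain with no ring can enter without a step that can be read. Nothing at hand accounts for this outcome.

What the compounds shown leave open is how far this tolerance reaches: a shorter chain, a longer chain such as octyl, a branched chain such as isopentyl, or a chain ending in an amine or a carboxylic acid could each hold the value or depart from it. They also leave open whether the pentyl chain and the 2-chlorophenyl group would remain indistinguishable in any read-out other than this one.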